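The source may hold more compounds than are shown below. What is called first, only, known or untested is meant among the compounds shown, and "the series" means these compounds.

Measured compounds:
- compound 1, `[N-]=[N+]=Nc1ccc(CC[C@H](O)/C=C/[C@@H]2[C@@H](C/C=C\CCCC(=O)O)[C@@H](O)C[C@H]2O)c(O)c1`, gives 220000 nM in an assay for displacement of a labelled ligand from prostaglandin F2-alpha receptor (Bos taurus); a lower number here means a stronger inhibitor, a higher number a weaker inhibitor
- compound 2, `[N-]=[N+]=Nc1ccc(CC[C@H](O)/C=C/[C@@H]2[C@@H](C/C=C\CCCC(=O)O)[C@@H](O)C[C@H]2O)cc1I`, gives 7000 nM in this assay

For the measured compounds named here, of these two, compound 2 has the lowest number in this assay; the only measured step is a 31-fold lower number from compound 1 to compound 2 (1.50 log units; beyond the scatter), which exchanges one substituted ring for another and leaves the chain untouched.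

Compound 3, `[N-]=[N+]=Nc1ccc(CC[C@@H](O)/C=C/[C@@H]2[C@@H](C/C=C\CCCC(=O)O)[C@@H](O)C[C@H]2O)cc1I`, keeps every atom and bond of compound 2 and changes only one thing: the two compounds have the same atoms and bonds; at least one stereo element is drawn with a configuration in one of them and without one in the other: 1 of 8 stereo elements differ; a stereocentre at a saturated chain carbon is drawn S in compound 2 and R in compound 3. Going by the values given here, no measured step involves a change of configuration, so the one step known, a 31-fold lower number from compound 1 to compound 2 (1.50 log units; beyond the scatter), gives no guide to its size or direction. With nothing measured to anchor it, the expectation is a number for compound 3 somewhat higher than that of compound 2, held within a wide range.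

For compound 3 the estimate in this assay is 30000 nM, ranging from 7000 nM to 150000 nM.

That estimate corresponds to an expected step of a 4.3-fold higher number from compound 2 to compound 3 (0.63 log units; beyond the scatter).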

Compound 3, half-maximal inhibitory concentration: 68000 nM
Beside the measured number, compound 3's estimate is 2.3-fold (0.36 log units) below it; the range from low to high includes it.
By their numbers in this assay, from the lowest: compound 2; then compound 3; then compound 1.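

For the compounds shown here, until now the only measured change had replaced one substituted ring with another, so nothing showed whether this assay could distinguish compounds with identical atoms and bonds. It can: changing a saturated chain carbon from S to R, with the 4-azido-3-iodophenyl ring and everything else kept, gives a 9.7-fold higher number from compound 2 to compound 3 (0.99 log units; beyond the scatter). Thus the spatial arrangement at this one chain carbon matters on its own, with the S form giving the lower number, though one caution applies to this reading: the fact that one of compounds 2 and 3 is drawn with a defined configuration and the other without, at the place where they differ

From the compounds shown here alone, it remains open whether the same S to R change would give a step of similar size and direction with the 4-azido-2-hydroxyphenyl ring of compound 1. Also open, going by these compounds, is how a ketone at this chain carbon, or a longer chain between it and the ring, would compare with compound 2.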